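Trimethoxyphenyl benzimidazoles: swapping the aryl substituent

The compounds below may be only part of what the source reports. "The series", "measured", "known", "first", "only" and "open" are said of these compounds alone.

Measured compounds:
compound 1, `COc1cc(-n2cnc3ccc(-c4ccc(C(F)(F)F)cc4)cc32)cc(OC)c1OC`: 890 nM
compound 2, `COc1cc(-n2cnc3ccc(-c4cccc([N+](=O)[O-])c4)cc32)cc(OC)c1OC`: 380 nM

In a functional assay on SGC-7901 cells (Homo sapiens) for antiproliferative activity, read by MTT assay, with a stated time of 72 h (a higher number here means a weaker inhibitor, a lower number a stronger inhibitor), compound 1 stands highest of the two numbers, the nearest being compound 2. Among the measured compounds shown here, the single measured step, a 2.3-fold lower number from compound 1 to compound 2 (0.37 log units; beyond the scatter), shows that exchanging the aryl group moves the number modestly. Compound 3, `COc1cccc(-c2ccc3ncn(-c4cc(OC)c(OC)c(OC)c4)c3c2)c1`, differs from compound 1 by 3-methoxyphenyl in place of 4-(trifluoromethyl)phenyl on an aromatic carbon. For the measured compounds named here, only that one step bears on this change, so a modest shift at most is expected, likely toward a lower number, though possibly within the scatter. Compound 3 is expected to give 600 nM (range 250 nM to 1500 nM), a step of a 1.5-fold lower number from compound 1 to compound 3 (0.17 log units; within the scatter).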

Compound 3, half-maximal inhibitory concentration: 3310 nM
Compound 3: the middle estimate sits 5.5-fold (0.74 log units) below what was measured; the whole stated range lies below it.
By their numbers in this assay, from the lowest: compound 2; then compound 1; then compound 3.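

In this assay this position proves able to move the number in both directions: a 3.7-fold higher number from compound 1 to compound 3 (0.57 log units; beyond the scatter) runs opposite to the earlier step, leaving compound 1 between the other two. With only methoxy in place of nitro on the same ring carbon, an 8.7-fold higher number from compound 2 to compound 3 (0.94 log units; beyond the scatter) is the largest step shown, so the place of the substituent alone does not set the number. Nothing shown accounts for this difference. As far as these compounds go, whether an amine or a carboxylic acid on that ring carbon would fall nearer compound 2 or compound 3 remains open, as does how 4-methoxyphenyl would compare with compound 3.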